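From compound 3 to compound 4: a ring exchange

This account rests on a few compounds, and the source may have more. Where it says the series, first, only, none or still open, it means among the compounds named here.

For the measured compounds named here, in an ADME assay on microsomes from liver (Mus musculus) for metabolic stability (on this read-out lower numbers stand for a shorter-lived compound and higher numbers for a longer-lived compound), compound 3 `Cc1nc(C(c2ccc(-c3ccc4cccc(F)c4c3)[nH]c2=O)C(C)C)[nH]c1C` gives 0.0817 h, the only number among the measured compounds. Compound 1 `CC(C)C(Cc1ncc[nH]1)c1ccc(-c2ccc3cccc(F)c3c2)[nH]c1=O` stands at a limit of the assay, < 0.0667 h. Compound 2 `CC(C)C(Cc1nnc[nH]1)c1ccc(-c2ccc3cccc(F)c3c2)[nH]c1=O` stands at the same limit, < 0.0667 h. Between these two, the comparison is a step that the two limits leave unreadable from compound 1 to compound 2.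

Compound 4 `CC(C)C(c1ccc(-c2ccc3cccc(F)c3c2)[nH]c1=O)N1CCNC1=O` carries 2-oxoimidazolidin-1-yl in place of 4,5-dimethyl-1H-imidazol-2-yl on a saturated chain carbon bound to an aromatic carbon and a saturated chain carbon.

Two measured steps change the group at this same carbon: an at least 1.2-fold higher number from compound 1 to compound 3 (0.08 log units; that floor lies within the scatter), and an at least 1.2-fold higher number from compound 2 to compound 3 (0.08 log units; that floor lies within the scatter). Going by the values given here, both are readable only as floors, and neither introduces 2-oxoimidazolidin-1-yl, so they give no sign of a step of any particular size or direction. The expectation therefore stays anchored on compound 3 at 0.0817 h. The expected change is a 1.1-fold higher number from compound 3 to compound 4 (0.04 log units; within the scatter), which means no step beyond the scatter in this assay. A report of only a limit is also expected to be quite possible. For compound 4 the estimated half-life is 0.09 h, with an expected range of 0.05 h to 0.25 h.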

Compound 4, half-life: 0.682 h
For compound 4 the middle estimate is 7.6-fold (0.88 log units) below the measured one; the measured number lies above the stated range.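

At the saturated chain carbon bound to an aromatic carbon and a saturated chain carbon, the exchange of an aromatic ring for the non-aromatic 2-oxoimidazolidin-1-yl gives, in this assay, a step with numbers at both ends that lies beyond the scatter: an 8.3-fold higher number from compound 3 to compound 4 (0.92 log units; beyond the scatter). Against the groups of the two earlier compounds that carry a methylene-linked ring, the same group gives an at least 10-fold higher number from compound 2 to compound 4 (1.00 log units; beyond the scatter) and an at least 10-fold higher number from compound 1 to compound 4 (1.00 log units; beyond the scatter), whereas the floors from those compounds to compound 3 stayed within the scatter. These two new steps are floors and not sizes, and the step from compound 1 to compound 2 cannot be read, all of them resting on a limit of the assay: the limit of < 0.0667 h in this assay, at which 2 of the 4 values shown sit.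

Compound 4 loses the aromatic ring, gains a carbonyl and attaches through a ring nitrogen in a single step, so the compounds shown do not separate these three changes. Also open, on these data alone, is where an open-chain urea, a six-membered cyclic urea or a pyrrolidin-2-one at this carbon would stand in this assay.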